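Nitro in place of methyl: expected growth inhibition

This account rests on a few compounds, and the source may have more. Where it says the series, first, only, none or still open, it means among the compounds named here.

Of the compounds shown here, two have numbers so far. Compound 1 `Cc1ccc2c(c1)/C(=C\C(=O)OC(C)(C)C)C(=O)N2` bears a methyl group on its aromatic ring; in a functional assay on MDA-MB-231 cells (Homo sapiens) for inhibition, read by CCK-8 assay, with a stated time of 72 h, tested at 20 uM (on this read-out higher numbers stand for more inhibition of growth at the one concentration tested and lower numbers for less inhibition of growth), compound 1 gives 87.8%. Compound 2 `CC(C)(C)OC(=O)/C=C1/C(=O)Nc2c(Cl)cccc21` bears chlorine in a different position of the same core, and in this assay compound 2 gives 87.4%. Compound 1 has the larger of the two figures on paper, but the gap to compound 2 falls within the scatter of repeated measurements, so the two values cannot be told apart.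

Compound 3 `CC(C)(C)OC(=O)/C=C1/C(=O)Nc2ccc([N+](=O)[O-])cc21` has not yet been measured. It differs from compound 1 by nitro in place of methyl on an aromatic carbon. Among the compounds with values here, no measured pair shows this change, so no step size is known for it. Both measured compounds sit high in this assay, close to the top of the read-out, leaving little room upward. The step from compound 1 to compound 3 is therefore expected to be a number 4.8 percentage points lower from compound 1 to compound 3 (within the scatter), within the scatter. Compound 3 is expected to give about 83% in this assay, in a range from 65% to 95%.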

Compound 3, percent growth inhibition at one concentration: 86.9%
Compound 3: middle estimate off by 3.9 percentage points, on the low side; low and high end bracket the measured number.
By their numbers in this assay, from the lowest: compounds 3, 2 and 1 (each within the scatter of the next).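

In this assay, nitro in place of methyl on an aromatic carbon gives a number 0.9 percentage points lower from compound 1 to compound 3 (within the scatter). Within the data shown here, this is the first step between compounds that differ in one place, and it shows that this position, meta to a fused ring and para to a fused ring, takes either group with no difference the read-out can separate, even though the entering nitro brings 3 heavy atoms and 2 hydrogen-bond acceptors where the methyl had 1 heavy atom and 0 acceptors. Nothing at hand explains this flat step.

Among these compounds, what remains open is whether this tolerance extends to other groups at the same carbon, such as an amine, a carboxylic acid or a longer chain, since methyl and nitro are the only pair read here. With readings at one concentration and all of them high, the data also cannot say whether compound 1 and compound 3 would separate in a read-out across several concentrations.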